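The source may report more compounds than this note shows. Statements on the series, on what has been measured and on what is new or still open speak of the compounds shown alone.

Measured compounds:
compound 1 `FC(F)(F)c1ccc(CN2CCN(Cc3cc(-c4ccc(OCc5ccccc5)cc4)on3)CC2)cc1` gives 2900 nM in a functional assay on MCF7 cells (Homo sapiens) for antiproliferative activity, read by sulforhodamine B assay, with a stated time of 72 h; a higher number here means a weaker inhibitor, a lower number a stronger inhibitor
compound 2 `N#Cc1cccc(COc2ccc(-c3cc(CN4CCN(Cc5ccc(C(F)(F)F)cc5)CC4)no3)cc2)c1` gives 800 nM in this assay
compound 3 `COc1cc(COc2ccc(-c3cc(CN4CCN(Cc5ccc(C(F)(F)F)cc5)CC4)no3)cc2)cc(OC)c1` gives 100 nM in this assay

Compound 2 sits at the second highest of the three numbers: compound 1 lies nearest, with a 3.6-fold lower number from compound 1 to compound 2 (0.56 log units; beyond the scatter) separating them, and compound 3 lies furthest, with an 8.0-fold lower number from compound 2 to compound 3 (0.90 log units; beyond the scatter). The third measured step, a 29-fold lower number from compound 1 to compound 3 (1.46 log units; beyond the scatter), is the largest of the set. All three steps concern the group on the oxygen at the far end of the core; none touches the amine nitrogen in a ring.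

Compound 4 `N#Cc1cccc(COc2ccc(-c3cc(CN4CCN(c5ccc(C(F)(F)F)cc5)CC4)no3)cc2)c1` is the next compound. Relative to compound 2 the change is 4-(trifluoromethyl)phenyl in place of 4-(trifluoromethyl)benzyl on an amine nitrogen in a ring. No measured step bears on this position, so the expectation for compound 4 in this assay cannot be anchored to a shown step; the direction is open and a small to modest change either way is as plausible as none beyond the scatter. The estimate for compound 4 is therefore kept close to compound 2 with a wide range: 1500 nM (range 250 nM to 9000 nM), meaning an expected step of a 1.9-fold higher number from compound 2 to compound 4 (0.27 log units; within the scatter).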

Compound 4, half-maximal inhibitory concentration: 2000 nM
The estimate for compound 4 lay 1.3-fold (0.12 log units) below the measured number, within the range that was stated.
By their numbers in this assay, from the lowest: compound 3; then compound 2; then compounds 4 and 1 (each within the scatter of the next).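

The amine nitrogen in a ring is now shown to matter in this assay, a position the earlier steps left untouched: 4-(trifluoromethyl)phenyl in place of 4-(trifluoromethyl)benzyl gives a 2.5-fold higher number from compound 2 to compound 4 (0.40 log units; beyond the scatter). The two groups have the same aromatic ring, the same trifluoromethyl group, no hydrogen-bond donors or acceptors and no net charge, and differ by one carbon atom, so a change of this small size is enough to give a step beyond the scatter at this nitrogen. Nothing available here accounts for the step.

On these data alone, this step is read only with the 3-cyanophenyl group at the far end, so its size alongside the 3,5-dimethoxyphenyl group of compound 3 remains open. Also open, as far as these compounds go, is how a longer chain such as 2-phenylethyl, or a carbonyl-linked benzoyl group, would behave on this nitrogen.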